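Phenylsulfonyl in place of thiophenylsulfonyl on a second core

The compounds below may be only part of what the source reports. "The series", "measured", "known", "first", "only" and "open" are said of these compounds alone.

Compound 1, `O=C(NC[C@H](NS(=O)(=O)c1cccs1)C(=O)O)c1cc2cc(CCC3CCNCC3)sc2s1`, in a functional assay for binding affinity, with Homo sapiens as the target, read by fluorescence and flow cytometry (on this read-out higher numbers stand for weaker binding and lower numbers for tighter binding), gives 0.15 nM.
Compound 2, `O=C(NC[C@H](NS(=O)(=O)c1ccccc1)C(=O)O)c1cc2cc(CCC3CCNCC3)sc2s1`, in this assay gives 0.023 nM.
Compound 3, `O=C(NC[C@H](NS(=O)(=O)c1cccs1)C(=O)O)c1cc2sc(CCC3CCNCC3)cc2s1`, in this assay gives 0.092 nM.

Compounds 1 and 2 share one core and differ by phenyl in place of thiophen-2-yl on a sulfonyl sulfur. That change gave a 6.5-fold lower number from compound 1 to compound 2 (0.81 log units; beyond the scatter) in this assay. Compound 3 carries the same atoms as compound 1 joined differently; the difference between the two cores is not broken down here. Its value and that of compound 1 lie within the scatter of each other, so nothing separates them.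

Compound 4, `O=C(NC[C@H](NS(=O)(=O)c1ccccc1)C(=O)O)c1cc2sc(CCC3CCNCC3)cc2s1`, is not yet measured in this assay. Within the data shown here, it differs from compound 3 by phenyl in place of thiophen-2-yl on a sulfonyl sulfur, the same change as the one from compound 1 to compound 2, at the same place. Because a 6.5-fold lower number from compound 1 to compound 2 (0.81 log units; beyond the scatter) was a modest step beyond the scatter, compound 4 is expected to give a step of about a 6.1-fold lower number from compound 3 to compound 4 (0.79 log units; beyond the scatter) from compound 3 in this assay. Compound 4 is therefore estimated at 0.015 nM in this assay, between 0.005 nM and 0.045 nM, resting on one observed pair only.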

Compound 4, dissociation constant: 0.15 nM
Compound 4: the middle estimate sits 10-fold (1.00 log units) below what was measured; measured number outside the range, above it.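

On the core of compound 3, phenyl in place of thiophen-2-yl on a sulfonyl sulfur gave a 1.6-fold higher number from compound 3 to compound 4 (0.21 log units; within the scatter) in this assay, so the lower number seen on the core of compound 1 did not recur and compound 3 and compound 4 are not separated. The size of the step on one core therefore did not carry over to the other, and the two steps disagree: the same change on two cores in this assay, a 6.5-fold lower number (0.81 log units; beyond the scatter) from compound 1 to compound 2 and a 1.6-fold higher number (0.21 log units; within the scatter) from compound 3 to compound 4, 11-fold (1.03 log units) apart, beyond the scatter of two such steps. This shows that in this series the effect of the change cannot be taken from one core to the other, but with a single pair on each core it does not show what in the cores sets the two steps apart.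

The compounds shown leave open whether a methyl or a benzyl group on the sulfonyl sulfur would behave alike on both cores. They also leave open whether the gap between the two steps would hold with an amide in place of the carboxylic acid.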